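The source may report more compounds than this note shows. Statements on the series, on what has been measured and on what is new or still open speak of the compounds shown alone.

Compound 1 `Cc1nc(-c2cccs2)sc1COc1ccc2c(c1)OCC2CC(=O)O`: in a functional assay on CHO cells for agonist activity at Free fatty acid receptor 1 (Homo sapiens), read by FLIPR and calcium flux, tested at 100 nM (on this read-out higher numbers stand for a stronger effect at the one concentration tested and lower numbers for a weaker effect), compound 1 gives 35.2%.
Compound 2 `Cc1nc(-c2ccc(Cl)s2)sc1COc1ccc2c(c1)OCC2CC(=O)O`: compound 2 gives 8.34%.
Compound 3 `Cc1nc(-c2cc3ccccc3o2)sc1COc1ccc2c(c1)OCC2CC(=O)O`: compound 3 gives 14.8%.

Compound 3 stands second of these three; one gap is a number 6.5 percentage points higher from compound 2 to compound 3 (within the scatter), while the other is a number 20.4 percentage points lower from compound 1 to compound 3 (beyond the scatter). Compound 4 `Cc1cccc(-c2nc(C)c(COc3ccc4c(c3)OCC4CC(=O)O)s2)c1` carries a different group at the same carbon: 3-methylphenyl in place of 1-benzofuran-2-yl on an aromatic carbon. The steps that swap the group at this carbon are a number 20.4 percentage points lower from compound 1 to compound 3 (beyond the scatter) and a number 6.5 percentage points higher from compound 2 to compound 3 (within the scatter), and the thiophen-2-yl of compound 1 gave the highest number. Among the compounds with values here, no measured step brings in 3-methylphenyl, so the direction is uncertain, with a moderate rise expected. Compound 4 is therefore estimated at 25%, within 6% to 50%, an expected step of a number 10.2 percentage points higher from compound 3 to compound 4 (beyond the scatter).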

Compound 4, a percentage reported as activity, at one concentration (the size of the read-out at that concentration, not a potency): 47.2%
Compound 4: middle estimate off by 22.2 percentage points, on the low side, within the range that was stated.
By their numbers in this assay, from the lowest: compounds 2 and 3 (each within the scatter of the next); then compound 1; then compound 4.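

In this assay, within the data shown here, 3-methylphenyl is the first group at this carbon to exceed thiophen-2-yl, with a number 12 percentage points higher from compound 1 to compound 4 (beyond the scatter). The larger steps, a number 32.4 percentage points higher from compound 3 to compound 4 (beyond the scatter) and a number 38.9 percentage points higher from compound 2 to compound 4 (beyond the scatter), show that the earlier drops with 5-chlorothiophen-2-yl and 1-benzofuran-2-yl did not extend to every replacement of thiophen-2-yl. No measurement at hand gives a reason for these differences. The compounds shown leave open what an unsubstituted phenyl would give at this carbon, and so what the methyl contributes. They also leave open what a methoxy or an amine in place of that methyl would give.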